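Sulfonamide tail variation on the shared core

A few compounds are considered here, and "the series" means these few. Any claim that something is new, unique, unknown or untested is made for them only; others in the source may bear on it.

Measured so far:
compound 1, `CCCn1c(=O)c2nc(-c3ccc(OCC(=O)NCCN=C(S)Nc4ccc(Br)cc4)cc3)[nH]c2n(CCC)c1=O`, 7.26 nM
compound 2, `CCCn1c(=O)c2nc(-c3ccc(OCC(=O)NCCNS(=O)(=O)c4cccc(S(=O)(=O)Cl)c4)cc3)[nH]c2n(CCC)c1=O`, 2.5 nM

In an assay on brain for binding affinity to adenosine receptor A1 (Rattus norvegicus), read by radioligand binding (a lower number here means a stronger inhibitor, a higher number a weaker inhibitor), compound 2 gives the lowest of the two numbers; its nearest neighbour is compound 1, whose value stands higher by a margin beyond the scatter. Compound 3, `CCCn1c(=O)c2nc(-c3ccc(OCC(=O)NCCNS(=O)(=O)c4ccc(C)cc4)cc3)[nH]c2n(CCC)c1=O`, differs from compound 2 in one place: 4-methylphenyl in place of 3-(chlorosulfonyl)phenyl on a sulfonyl sulfur. Among the compounds with values here, no step between measured compounds covers this kind of change, and the two known values say nothing about how the group on the sulfonyl sulfur affects the read-out. The expectation is a small step from compound 2 toward a higher number, or none beyond the scatter, as a 1.6-fold higher number from compound 2 to compound 3 (0.20 log units; within the scatter) expresses. Compound 3 is accordingly estimated at 4 nM in this assay, with a range from 1.5 nM to 12 nM.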

Compound 3, inhibition constant: 72 nM
Compound 3: middle estimate off by 18-fold (1.26 log units), on the low side; the whole stated range lies below it.
By their numbers in this assay, from the lowest: compound 2; then compound 1; then compound 3.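

In this assay the group on the sulfonyl sulfur is far from a silent part of the tail: a 29-fold higher number from compound 2 to compound 3 (1.46 log units; beyond the scatter) for 4-methylphenyl in place of 3-(chlorosulfonyl)phenyl, although a six-membered aromatic ring of carbon stays on the sulfur in both. A sulfonamide tail as such does not secure a low number, since the other listed change, replacing the bromine-bearing tail with the tail carrying the sulfonyl sulfur, gives a 9.9-fold higher number from compound 1 to compound 3 (1.00 log units; beyond the scatter) in this same read-out. Nothing measured on hand accounts for either step.

The compounds shown do not separate the loss of the chlorosulfonyl group from the gain of the methyl group. On these data alone, how a plain phenyl, an amine or a carboxylic acid on that ring would read remains open.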